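Hydroxyphenyl ester variant in the aryl oxime ester series

The compounds below may be only part of what the source reports. "The series", "measured", "known", "first", "only" and "open" are said of these compounds alone.

Measured so far in a functional assay, with a stated time of 30 min; on this read-out lower numbers stand for stronger inhibition and higher numbers for weaker inhibition:
compound 1 `COc1ccc(C2CC(=NOC(=O)c3ccc(F)cc3)CC(c3ccc(OC)cc3)N2C)cc1`: 152000 nM
compound 2 `COc1ccc(C2CC(=NOC(=O)c3ccc(Br)cc3)CC(c3ccc(OC)cc3)N2C)cc1`: 121000 nM
compound 3 `COc1ccc(C2CC(=NOC(=O)c3ccccc3OC(C)=O)CC(c3ccc(OC)cc3)N2C)cc1`: 350000 nM

Compound 2 and compound 1 lie within the scatter of each other, as the step of a 1.3-fold lower number from compound 1 to compound 2 (0.10 log units; within the scatter) shows. Compound 3 stands apart from both: the steps of a 2.3-fold higher number from compound 1 to compound 3 (0.36 log units; beyond the scatter) and a 2.9-fold higher number from compound 2 to compound 3 (0.46 log units; beyond the scatter) are beyond the scatter, both toward weaker inhibition.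

Compound 4 `COc1ccc(C2CC(=NOC(=O)c3ccccc3O)CC(c3ccc(OC)cc3)N2C)cc1` has not been measured. Relative to compound 2 the change is 2-hydroxyphenyl in place of 4-bromophenyl on a carbonyl carbon. For the measured compounds named here, the step that bears on it most directly is a 2.9-fold higher number from compound 2 to compound 3 (0.46 log units; beyond the scatter), where a 2-acetoxyphenyl took the same place and weakened inhibition modestly; compound 4 carries the related 2-hydroxyphenyl, and no measured pair speaks to the hydroxy group itself. A modest move toward weaker inhibition in this assay is therefore expected, of about the size seen for compound 3, giving an expected step of a 2.1-fold higher number from compound 2 to compound 4 (0.33 log units; beyond the scatter). Compound 4 is expected to give 260000 nM, with a range of 110000 nM to 620000 nM.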

Compound 4, half-maximal inhibitory concentration: 29000 nM
For compound 4 the middle estimate is 9.0-fold (0.95 log units) above the measured one; measured number below the stated range.
By their numbers in this assay, from the lowest: compound 4; then compounds 2 and 1 (each within the scatter of the next); then compound 3.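

In this assay, removing the acetyl from the oxygen on the aromatic ring gives a 12-fold lower number from compound 3 to compound 4 (1.08 log units; beyond the scatter) and reverses the direction seen for the 2-acetoxyphenyl ester, so this substituent cannot be treated as interchangeable with its acetylated form. The 2-hydroxyphenyl group also improves on both halogenated esters, with a 4.2-fold lower number from compound 2 to compound 4 (0.62 log units; beyond the scatter) and a 5.2-fold lower number from compound 1 to compound 4 (0.72 log units; beyond the scatter) in the same assay, which makes compound 4 the strongest of the four and shows that replacing the 4-halophenyl group at this carbonyl carbon can move inhibition in either direction. No supporting data explain why the free hydroxy group has this effect.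

Going by these compounds, it remains open whether the gain requires a hydroxy group specifically, as 2-methoxyphenyl and 2-aminophenyl esters would test. The placement is also unresolved, since the 4-hydroxyphenyl ester does not appear among these compounds.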